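A few compounds are considered here, and "the series" means these few. Any claim that something is new, unique, unknown or untested is made for them only; others in the source may bear on it.

Working notes on the oxime-ether series. All three measured compounds share one core and differ only in the group on the oxime oxygen. Compound 1 `C/C(=N\OCc1ccncc1)c1ccc(Sc2cc(F)cc(C3CCOCC3)c2)cc1` gives 300 nM in a functional assay (blood) for inhibition, with Homo sapiens as the target; on this read-out lower numbers stand for stronger inhibition and higher numbers for weaker inhibition. Compound 2 `C/C(=N\OC(=O)C(C)(C)C)c1ccc(Sc2cc(F)cc(C3CCOCC3)c2)cc1` gives 40 nM in this assay, and compound 3 `C/C(=N\OCC(=O)O)c1ccc(Sc2cc(F)cc(C3CCOCC3)c2)cc1` gives 740 nM in this assay. Compound 3 therefore stands at the weak end of the set: its number is the highest of the three, and both steps to it lie beyond the scatter, a 2.5-fold higher number from compound 1 to compound 3 (0.39 log units; beyond the scatter) and a 19-fold higher number from compound 2 to compound 3 (1.27 log units; beyond the scatter).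

Compound 4 `C/C(=N\OC(C)C)c1ccc(Sc2cc(F)cc(C3CCOCC3)c2)cc1` is not yet measured. It differs from compound 3 in a single place: isopropyl in place of carboxymethyl on an oxygen. Both measured steps that end at compound 3 bear on this change, and in both the compound carrying the carboxy gives the higher number, modestly in a 2.5-fold higher number from compound 1 to compound 3 (0.39 log units; beyond the scatter) and strongly in a 19-fold higher number from compound 2 to compound 3 (1.27 log units; beyond the scatter). Isopropyl, like (pyridin-4-yl)methyl and (tert-butyl)carbonyl, carries no carboxy, so a lower number is expected for compound 4 in this assay, of a size somewhere between those two steps. Among the compounds with values here, no measured compound carries an isopropyl or any comparably small substituent on this oxygen, so the estimate is broad. Compound 4 is expected at 150 nM in this assay, within 40 nM to 600 nM. That estimate means an expected step of a 4.9-fold lower number from compound 3 to compound 4 (0.69 log units; beyond the scatter).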

Compound 4, half-maximal inhibitory concentration: 920 nM
Beside the measured number, compound 4's estimate is 6.1-fold (0.79 log units) below it, and the stated range ends below it.
By their numbers in this assay, from the lowest: compound 2; then compound 1; then compounds 3 and 4 (each within the scatter of the next).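

In this assay, within the data shown here, isopropyl in place of carboxymethyl on this oxygen makes no readable difference (a 1.2-fold higher number from compound 3 to compound 4 (0.09 log units; within the scatter)), so lacking a carboxy is not enough to give a lower number, and compound 4 goes against the link between carboxy and higher number that the earlier steps suggested. Isopropyl also falls well short of the other two groups without a carboxy, by a modest step against (pyridin-4-yl)methyl (a 3.1-fold higher number from compound 1 to compound 4 (0.49 log units; beyond the scatter)) and a large one against (tert-butyl)carbonyl (a 23-fold higher number from compound 2 to compound 4 (1.36 log units; beyond the scatter)), which leaves compound 2 alone at the low end and shows that the identity of the group matters more here than the presence or absence of a carboxy. Nothing at hand explains this result.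

Compound 2 combines a carbonyl on the oxygen with a tert-butyl, so a plain tert-butyl or an acetyl on this oxygen would be needed to show which part goes with its low number. A benzyl in place of (pyridin-4-yl)methyl, and a longer chain ending in a carboxylic acid, would likewise show how far compound 1 and compound 3 depend on the ring nitrogen and on chain length.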